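Varying the Aryl Group on the Ring Nitrogen

This account rests on a few compounds, and the source may have more. Where it says the series, first, only, none or still open, it means among the compounds named here.

Compound 1 `N#CC1=C(N)Oc2c(N)cc3nc4ccccc4nc3c2C12C(=O)N(Cc1cnnn1-c1cccc(Br)c1)c1ccccc12`: 18900 nM
Compound 2 `COc1ccccc1-n1nncc1CN1C(=O)C2(C(C#N)=C(N)Oc3c(N)cc4nc5ccccc5nc4c32)c2ccccc21`: 37500 nM
Compound 3 `N#CC1=C(N)Oc2c(N)cc3nc4ccccc4nc3c2C12C(=O)N(Cc1cnnn1-c1c(F)cccc1F)c1ccccc12`: > 50000 nM

Three compounds share one core and differ only in the aryl group that sits on an aromatic nitrogen of a five-membered aromatic ring with 3 nitrogen. In a functional assay on A549 cells (Homo sapiens) for antiproliferative activity, read by MTT assay, with a stated time of 48 h (on this read-out higher numbers stand for weaker inhibition and lower numbers for stronger inhibition), compound 1 gives 18900 nM. In this assay compound 2 gives 37500 nM. For compound 3 this assay reports only a limit, > 50000 nM. Compound 3 thus stands at the limit of > 50000 nM in this assay, at which 1 of the 3 values shown sits, the weakest point among the numbers shown, with the step of an at least 2.6-fold higher number from compound 1 to compound 3 (0.42 log units; beyond the scatter) beyond the scatter and the step of an at least 1.3-fold higher number from compound 2 to compound 3 (0.12 log units; that floor lies within the scatter) only a floor within it.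

Compound 4 `Cc1ccc(Cl)cc1-n1nncc1CN1C(=O)C2(C(C#N)=C(N)Oc3c(N)cc4nc5ccccc5nc4c32)c2ccccc21` has not yet been measured. (5-chloro-2-methylphenyl in place of 2,6-difluorophenyl on an aromatic nitrogen). The two measured steps into compound 3 show that the aryl group moves the number, and that 2,6-difluorophenyl gives the highest number of the three. Compound 4 carries a single halogen and a methyl rather than two fluorines, so a step back toward the numbers of compound 1 and compound 2 is expected, an at least 1.6-fold lower number from compound 3 to compound 4 (0.22 log units; that floor lies within the scatter), though a further limit cannot be excluded. Compound 4 is therefore estimated at 30000 nM, within a range from 12000 nM to 80000 nM.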

Compound 4, half-maximal inhibitory concentration: > 50000 nM
Compound 4 was reported as a limit; the forecaster's own chance of this, stated with the estimate: 35%; middle value at least 1.6-fold (0.22 log units) away from the limit.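

Compound 4, like compound 3, is held at a limit and not a number, so a second aryl group on this aromatic nitrogen ends at the same boundary of this assay: the limit of > 50000 nM in this assay, at which 2 of the 4 values shown sit.

With 5-chloro-2-methylphenyl in place of 3-bromophenyl there is an at least 2.6-fold higher number from compound 1 to compound 4 (0.42 log units; beyond the scatter), which shows that a step of this kind away from the 3-bromophenyl compound does not require 2,6-difluorophenyl or any fluorine at all. Against 2-methoxyphenyl the same group gives an at least 1.3-fold higher number from compound 2 to compound 4 (0.12 log units; that floor lies within the scatter), so this pair is not separated, and the step between the two compounds at the limit cannot be read.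

The compounds shown leave open how far the two limit compounds actually lie from each other, and whether any aryl group on this nitrogen gives a clearly lower number than the 3-bromophenyl group does. They also leave open what a phenyl ring carrying an amine or a carboxylic acid would do here, since every aryl group shown carries only halogen, methyl or methoxy.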